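Quinoline series: replacing the aryl ether with cyclohexyl

The source may report more compounds than this note shows. Statements on the series, on what has been measured and on what is new or still open speak of the compounds shown alone.

Three compounds of the series carry a measurement in an ADME assay for permeability, using PAMPA, with a stated time of 30 min, at pH 7.4; on this read-out higher numbers stand for higher permeability and lower numbers for lower permeability. Compound 1 `c1ccc(-c2ccc3c(NCCCNCc4ccco4)ccnc3c2)cc1` gives 237 10^-6 cm/s. Compound 2 `Fc1ccc(Oc2ccc3c(NCCCNCc4ccco4)ccnc3c2)cc1` gives 317 10^-6 cm/s. Compound 3 `COc1ccc(Oc2ccc3c(NCCCNCc4ccco4)ccnc3c2)cc1` gives 317 10^-6 cm/s. The measured steps are small throughout: a 1.3-fold higher number from compound 1 to compound 2 (0.13 log units; within the scatter), a 1.3-fold higher number from compound 1 to compound 3 (0.13 log units; within the scatter) and no change at the digits printed from compound 2 to compound 3 (within the scatter). Compound 3 therefore stands level with compound 2 at the digits shown, and its gap to compound 1 is within the scatter, so the three values describe one plateau rather than a ranking.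

Compound 4 `c1coc(CNCCCNc2ccnc3cc(C4CCCCC4)ccc23)c1` has not been measured in this assay. It differs from compound 3 as follows: cyclohexyl in place of 4-methoxyphenoxy on an aromatic carbon. For the measured compounds named here, no measured pair swaps an aromatic group for a saturated ring at this position, so no step addresses the change directly. What bears on it is the observation that changing the group at this same aromatic carbon among compounds 1, 2 and 3 gave steps within the scatter, the largest being a 1.3-fold higher number from compound 1 to compound 3 (0.13 log units; within the scatter). On that basis no step beyond the scatter is expected, and the estimate is a 1.1-fold lower number from compound 3 to compound 4 (0.04 log units; within the scatter) in this assay. Compound 4 is accordingly estimated at 290 10^-6 cm/s, with a range from 150 10^-6 cm/s to 520 10^-6 cm/s, the width reflecting the absence of a directly comparable step.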

Compound 4, apparent permeability: 23 10^-6 cm/s
Compound 4: the middle estimate sits 13-fold (1.10 log units) above what was measured; the whole stated range lies above it.
By their numbers in this assay, from the lowest: compound 4; then compounds 1, 2 and 3 (each within the scatter of the next).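

In this assay, for the compounds shown here, this aromatic carbon turns out not to be indifferent to its group: the earlier steps among aromatic groups stayed within the scatter, whereas cyclohexyl in place of 4-methoxyphenoxy gives a 14-fold lower number from compound 3 to compound 4 (1.14 log units; beyond the scatter) and cyclohexyl in place of 4-fluorophenoxy gives a 14-fold lower number from compound 2 to compound 4 (1.14 log units; beyond the scatter). The ether oxygen does not separate the compounds on the plateau from compound 4, since cyclohexyl in place of phenyl, a group with no such oxygen, also gives a large step, a 10-fold lower number from compound 1 to compound 4 (1.01 log units; beyond the scatter); among the compounds shown, all three that carry a six-membered aromatic ring here sit together and the one with a non-aromatic ring stands apart. No supporting data accompany these numbers, so the reason for this step remains unexplained.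

On these data alone, whether the step belongs to the loss of the aromatic ring in general or to cyclohexyl in particular stays open, and a pyridine ring, a piperidine ring or an open butyl chain on this carbon would help to separate the two readings. Cyclohexyloxy would show whether restoring the ether oxygen on the saturated ring changes the picture.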